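The source may hold more compounds than are shown below. What is called first, only, known or untested is meant among the compounds shown, and "the series" means these compounds.

Compound 1, `Cc1cc(-c2ccccc2)n(-c2nc(C(F)(F)F)cc(=O)[nH]2)n1`: > 50000 nM
Compound 2, `Cc1cc(NCCN(C)C)n(-c2nc(C(F)(F)F)cc(=O)[nH]2)n1`: "not determined" (no result reported)
Compound 3, `Cc1cc(NCCO)n(-c2nc(C(F)(F)F)cc(=O)[nH]2)n1`: "not determined" (no result reported)

In an ADME assay on CHO cells (Cricetulus griseus) for cytotoxicity, read by MTT assay (on this read-out lower numbers stand for stronger inhibition and higher numbers for weaker inhibition), compound 1 reaches only a limit of the assay, > 50000 nM. For compound 2 no result in this assay was reported, and the same holds for compound 3, so compound 3 has no number of its own to stand on. Among the compounds with values here, the only value shown around it is a limit: the limit of > 50000 nM in this assay, at which 1 of the 3 values shown sits. Compound 4, `Cc1cc(Nc2ccccn2)n(-c2nc(C(F)(F)F)cc(=O)[nH]2)n1`, differs from compound 3 by pyridin-2-yl in place of 2-hydroxyethyl on a nitrogen on an aromatic ring. No measured step covers this change, and the shown values point to no direction, so no step beyond the usual scatter is expected in this assay. Compound 4 is therefore expected to give 50000 nM, within 20000 nM to 100000 nM, most likely again only as a limit.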

Compound 4, half-maximal inhibitory concentration: 23000 nM
For compound 4 the middle estimate is 2.2-fold (0.34 log units) above the measured one; the measured number falls inside the stated range.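

In this assay, within the data shown here, compound 4 gives a single number, 23000 nM, the first such value at this position on the shared core. Putting (pyridin-2-yl)amino in place of phenyl on an aromatic carbon gives an at least 2.1-fold lower number from compound 1 to compound 4 (0.33 log units; beyond the scatter), so the read-out does respond to a change at this position. Compound 1 itself stands only at a limit: the limit of > 50000 nM in this assay, at which 1 of the 4 values shown sits.

As far as these compounds go, the true size of this step therefore stays open. From the compounds shown here alone, it also remains open whether the linking nitrogen or the pyridin-2-yl ring accounts for the change, and what a phenylamino group, a carboxylic acid or a longer alkyl chain would give here.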